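This account rests on a few compounds, and the source may have more. Where it says the series, first, only, none or still open, it means among the compounds named here.

Three compounds have been measured in a toxicity assay on the whole organism (strain Icem-CET (SPF Caw)) for cytotoxicity, with Mus musculus as the target; a higher number here means that more compound is needed for the effect, a lower number that less compound is needed:

Compound 1, `C#CCNC(=O)/C(C)=C(\C)c1ccc(OC)cc1`, gives 400 mg/kg.
Compound 2, `C#CCNC(=O)/C(C)=C(\C)c1cc(OC)c(OC)c(OC)c1`, gives 300 mg/kg.
Compound 3, `COc1ccc(/C(C)=C(\C)C(=O)NC2CC2)cc1`, gives 300 mg/kg.

Compound 1 and compound 3 share a core and differ in one place only: cyclopropyl in place of propargyl on an amide-type nitrogen. This change brought a 1.3-fold lower number from compound 1 to compound 3 (0.12 log units; within the scatter), a step that is within the scatter of repeated measurements of this kind, so the two numbers cannot be told apart with confidence. Compound 2 carries a different core; how its core differs from that of compound 1 is not broken down here. Its value sits level with that of compound 3 at the digits given, and the gap to compound 1 is likewise within the scatter, so none of the three can be called more or less toxic than the others.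

Compound 4, `COc1cc(/C(C)=C(\C)C(=O)NC2CC2)cc(OC)c1OC`, has not yet been measured in this assay. It stands to compound 2 exactly as compound 3 stands to compound 1, the same change in the same place: cyclopropyl in place of propargyl on an amide-type nitrogen. Since that change made only a small step between compound 1 and compound 3, as shown by a 1.3-fold lower number from compound 1 to compound 3 (0.12 log units; within the scatter), the step from compound 2 to compound 4 is expected to be of similar size, namely a 1.3-fold lower number from compound 2 to compound 4 (0.10 log units; within the scatter). Starting from the value of compound 2, 300 mg/kg, compound 4 is therefore estimated to give about 240 mg/kg, with a plausible range from 150 mg/kg to 420 mg/kg.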

Compound 4, dose for half-maximal effect: > 800 mg/kg
Compound 4 was reported as a limit; the forecaster's own chance of this, stated with the estimate: 5%; middle value at least 3.3-fold (0.52 log units) away from the limit.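

In this assay, putting cyclopropyl in place of propargyl on an amide-type nitrogen did not behave alike on the two cores, giving an at least 2.6-fold higher number from compound 2 to compound 4 (0.42 log units; beyond the scatter) on the second core, while the same change on the first core stayed within the scatter: the same change on two cores in this assay, a 1.3-fold lower number (0.12 log units; within the scatter) from compound 1 to compound 3 and an at least 2.6-fold higher number (0.42 log units; beyond the scatter) from compound 2 to compound 4, at least 3.5-fold (0.55 log units) apart, beyond the scatter of two such steps

Compound 4 gives > 800 mg/kg, which is a limit of the assay and not a number, so the step has a lower bound but no known full size: the limit of > 800 mg/kg in this assay, at which 1 of the 4 values shown sits.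

For the compounds shown here, this shows that, in these two pairs, the result of the change on one core could not be carried over to the other, but with only two pairs it gives no general rule for the series and no reason for the difference.

The compounds shown leave open whether the large step belongs to cyclopropyl itself or would also appear with another small group on the same nitrogen, such as isopropyl or cyclobutyl. They also leave open how a third core would respond to the same change, and how far the number for compound 4 really lies past the limit.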